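Working notes: 4-methylphenyl to 4-chlorophenyl

The source may report more compounds than this note shows. Statements on the series, on what has been measured and on what is new or still open speak of the compounds shown alone.

Three compounds on one shared core have numbers in a functional assay on HepG2 cells (Homo sapiens) for inhibition, read by MTT assay, with a stated time of 72 h (on this read-out higher numbers stand for weaker inhibition and lower numbers for stronger inhibition), so far. Compound 1 `COc1ccc(-c2nnc(SCCCN3CCN(c4nc5ccccc5s4)CC3)o2)cc1` reads 134000 nM and compound 2 `O=[N+]([O-])c1ccc(-c2nnc(SCCCN3CCN(c4nc5ccccc5s4)CC3)o2)cc1` reads 93300 nM while compound 3 `Cc1ccc(-c2nnc(SCCCN3CCN(c4nc5ccccc5s4)CC3)o2)cc1` reads 96700 nM on the same scale. Compound 3 stands within the scatter of both others, so these numbers give no order among the three.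

Compound 4 `Clc1ccc(-c2nnc(SCCCN3CCN(c4nc5ccccc5s4)CC3)o2)cc1` differs from compound 3 by chloro in place of methyl on an aromatic carbon in one place: chloro in place of methyl on an aromatic carbon, para to a large group. The measured steps that bear on this change are a 1.4-fold lower number from compound 1 to compound 3 (0.14 log units; within the scatter) and a 1.4-fold lower number from compound 1 to compound 2 (0.16 log units; within the scatter) and also a 1.0-fold higher number from compound 2 to compound 3 (0.02 log units; within the scatter) on that same aromatic carbon. All three lie within the scatter across methoxy, nitro and methyl. For the measured compounds named here, no chloro compound has been measured yet, so this small set is the only guide.

No step beyond the scatter is therefore expected in this assay for this change. The estimated step is a 1.1-fold lower number from compound 3 to compound 4 (0.03 log units; within the scatter) and would mark no real shift. For compound 4 the estimate is 90000 nM with an expected range of 50000 nM to 160000 nM as the working bounds.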

Compound 4, half-maximal inhibitory concentration: 87700 nM
Compound 4: the middle estimate sits 1.0-fold (0.01 log units) above what was measured; low and high end bracket the measured number.
By their numbers in this assay, from the lowest: compounds 4, 2, 3 and 1 (each within the scatter of the next).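

In this assay, chloro on this aromatic carbon of the six-membered ring, para to a large group, brings a fourth substituent into the comparison, and each new step stays within the scatter (a 1.1-fold lower number from compound 3 to compound 4 (0.04 log units; within the scatter)) (a 1.1-fold lower number from compound 2 to compound 4 (0.03 log units; within the scatter)) (a 1.5-fold lower number from compound 1 to compound 4 (0.18 log units; within the scatter)). Chloro therefore joins methoxy, nitro and methyl without opening any separation, and none of the four compounds goes against this flat picture. The four readings give no order among the substituents at this position, and no measurement available here accounts for that flat picture.

On these data alone, whether an amine or a carboxylic acid on this same aromatic carbon would move the number beyond the scatter remains open. Also open is whether a change away from this carbon, such as a longer chain elsewhere on the shared core, would shift the reading in this assay when the substituents shown here do not.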